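A few compounds are considered here, and "the series" means these few. Any claim that something is new, unique, unknown or untested is made for them only; others in the source may bear on it.

Working notes on the series. The shared core of compound 1 `CC(C)(C)N(NC(=O)c1ccccc1)C(=O)c1ccccc1Cl` carries a chloro group on one of its two aromatic rings; in an assay on cells for agonist activity at ecdysone receptor (Bombyx mori), read by a luciferase reporter, with a stated time of 24 h (a lower number here means that less compound is needed, a higher number that more compound is needed for the effect), compound 1 gives 75.9 nM. Compound 2 `CC(C)(C)N(NC(=O)c1ccccc1)C(=O)c1ccccc1Br` has the same core with bromo in place of that chloro, and in this assay compound 2 gives 170 nM. For the measured compounds named here, the single measured step is a 2.2-fold higher number from compound 1 to compound 2 (0.35 log units; beyond the scatter). Going by the values given here, of the two numbers in hand, compound 2 stands at the highest, with compound 1 as its only neighbour.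

Compound 3 `CC(C)(C)N(NC(=O)c1ccccc1)C(=O)c1ccc(Cl)cc1Cl` has not been measured. Its difference from compound 2 is 2,4-dichlorophenyl in place of 2-bromophenyl on a carbonyl carbon. The step from compound 1 to compound 2 bears on it in one part only: exchanging bromo for chloro ran the number up by a modest margin, so the reverse exchange alone would be expected to bring it back toward compound 1. Among the compounds with values here, the second chlorine on that ring has no measured counterpart, so its contribution is unknown. On that basis compound 3 is expected to show a 1.7-fold lower number from compound 2 to compound 3 (0.23 log units; within the scatter), with an estimated value of 100 nM and a range from 30 nM to 350 nM.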

Compound 3, half-maximal effective concentration: 117 nM
For compound 3 the middle estimate is 1.2-fold (0.07 log units) below the measured one, and the stated range covers the measured number.
By their numbers in this assay, from the lowest: compounds 1, 3 and 2 (each within the scatter of the next, the first and the last beyond it).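

In this assay, the second chlorine can now be read on its own: chloro in place of hydrogen on an aromatic carbon gives a 1.5-fold higher number from compound 1 to compound 3 (0.19 log units; within the scatter), so adding this atom to the ring of compound 1 produces no difference beyond the scatter. The other step, a 1.5-fold lower number from compound 2 to compound 3 (0.16 log units; within the scatter), also stays within the scatter, so 2,4-dichlorophenyl in place of 2-bromophenyl on a carbonyl carbon does not separate these two compounds, and only the two ends of the series, compound 1 and compound 2, remain apart. No supporting data bear on what lies behind these steps.

The compounds shown leave open whether this ring accepts groups other than halogens, such as methyl, methoxy, an amine or a carboxylic acid, in place of the chloro atoms, and whether any of them would move the number beyond the scatter. Going by these compounds, the other aromatic ring carries no substituent in compound 1, compound 2 or compound 3, so the effect of placing a chloro or methoxy group on it also remains open.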